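From methoxy to chloro on the shared core

The source may hold more compounds than are shown below. What is called first, only, known or untested is meant among the compounds shown, and "the series" means these compounds.

- Compound 1 `COc1nc(F)nc2c1ncn2[C@H]1C[C@H](N=[N+]=[N-])[C@@H](CO)O1`: 9400 nM
- Compound 2 `COc1nc(OC)c2ncn([C@H]3C[C@H](N=[N+]=[N-])[C@@H](CO)O3)c2n1`: > 100000 nM, a limit

Within the data shown here, in an ADME assay on PBMC cells (Homo sapiens) for cytotoxicity, with a stated time of 5 days (a higher number here means a weaker inhibitor, a lower number a stronger inhibitor), compound 1 gives 9400 nM, the only actual number so far. Compound 2 gives only a limit, > 100000 nM.

Compound 3 `[N-]=[N+]=N[C@H]1C[C@H](n2cnc3c(Cl)nc(F)nc32)O[C@@H]1CO` carries chloro in place of methoxy on an aromatic carbon. Among the measured compounds shown here, the one measured step, an at least 10-fold higher number from compound 1 to compound 2 (1.02 log units; beyond the scatter), put methoxy in place of the fluoro group that compound 3 keeps, so it bears only loosely on this change. It weakly suggests a small move toward a lower number in this assay, possibly within the scatter. The expected step is a 1.6-fold lower number from compound 1 to compound 3 (0.19 log units; within the scatter). For compound 3 the estimated value is 6000 nM, with an expected range from 1200 nM to 30000 nM.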

Compound 3, half-maximal inhibitory concentration: 7200 nM
Beside the measured number, compound 3's estimate is 1.2-fold (0.08 log units) below it; the range from low to high includes it.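

In this assay, the step at this position, a 1.3-fold lower number from compound 1 to compound 3 (0.12 log units; within the scatter), lies within the scatter, so chloro and methoxy on this aromatic carbon next to the ring nitrogen cannot be told apart while the fluoro group stays in place. The earlier compounds shown here showed a large step only for methoxy in place of fluoro, not for any change at this position. Nothing shown gives a cause for this result.

On these data alone, only methoxy and chloro are compared here, so the effect of an amine or a longer chain at this position remains open.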